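Thiouridine monophosphates at the purinoceptor: benzyl replaces methyl

The compounds below may be only part of what the source reports. "The series", "measured", "known", "first", "only" and "open" are said of these compounds alone.

Measured compounds:
compound 1, `CCSc1nc(=O)ccn1[C@@H]1O[C@H](COP(=O)(O)O)[C@@H](O)[C@H]1O`: 1500 nM
compound 2, `CSc1nc(=O)ccn1[C@@H]1O[C@H](COP(=O)(O)O)[C@@H](O)[C@H]1O`: 2900 nM
compound 3, `CSc1nc(=O)ccn1[C@@H]1O[C@H](COP(=O)(O)OP(=O)(O)O)[C@@H](O)[C@H]1O`: 523 nM

All three were read in an in vitro functional assay on 1321-N1 cells for agonist activity at P2Y purinoceptor 2 (Homo sapiens), read by scintillation proximity assay and inositol phosphate accumulation; on this read-out higher numbers stand for an effect only at larger amounts of compound and lower numbers for an effect already at smaller amounts. Compound 2 carries the highest number of the three. Its nearest neighbour is compound 1, reached by a 1.9-fold higher number from compound 1 to compound 2 (0.29 log units; within the scatter), so the two cannot be told apart. Compound 3 is furthest away: the step of a 5.5-fold lower number from compound 2 to compound 3 (0.74 log units; beyond the scatter) is modest but real.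

Compound 4, `O=c1ccn([C@@H]2O[C@H](COP(=O)(O)O)[C@@H](O)[C@H]2O)c(SCc2ccccc2)n1`, has not yet been measured in this assay. It differs from compound 2 by phenyl in place of hydrogen on a saturated chain carbon bound to a sulfur, that is, methylsulfanyl becomes benzylsulfanyl.

Among the compounds with values here, the only measured step that touches this place is the one from compound 1 to compound 2, where the chain on the sulfur was shortened and the number barely moved. A phenyl is a larger addition than the methyl that was removed there, and nothing measured shows how this assay answers to a six-membered aromatic ring of carbon only at that position. The step is therefore expected to be small, most likely no change beyond the scatter, with some leaning towards a lower number given that the shorter chain in compound 2 sits at the top of the set.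

Compound 4 is estimated at 1500 nM, within 400 nM to 5000 nM, which is an expected step of a 1.9-fold lower number from compound 2 to compound 4 (0.29 log units; within the scatter).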

Compound 4, half-maximal effective concentration: >= 100000 nM
Compound 4: no number, only a limit (the forecaster's own chance of this, stated with the estimate: 10%); at least 66-fold (1.82 log units) between middle value and limit.
By their numbers in this assay, from the lowest: compound 3; then compounds 1 and 2 (each within the scatter of the next). At a limit, above all of these: compound 4.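

In this assay compound 4 stands at a limit and not at a number: the limit of >= 100000 nM in this assay, at which 1 of the 4 values shown sits.

The saturated chain carbon bound to a sulfur is therefore not an indifferent place: the earlier change there, a 1.9-fold higher number from compound 1 to compound 2 (0.29 log units; within the scatter), stayed within the scatter, whereas phenyl in place of hydrogen gives an at least 34-fold higher number from compound 2 to compound 4 (1.53 log units; beyond the scatter) and phenyl in place of methyl gives an at least 66-fold higher number from compound 1 to compound 4 (1.82 log units; beyond the scatter). The flat response between the two short chains on the sulfur does not carry over to benzylsulfanyl, and with a limit on one side, both new steps give only the least size of the change, not its full size.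

Open, on these data alone, is whether the loss belongs to the aromatic ring itself or to the greater reach of the group, which a longer chain such as butyl or a cyclohexyl in place of the phenyl would help to separate. Also open, as far as these compounds go, is whether the added phosphate that separates compound 3 from compound 2 would change anything when benzylsulfanyl replaces methylsulfanyl.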